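Furan-2-yl in Place of 3-Fluorophenyl on Compound 3

The source may hold more compounds than are shown below. What is called first, only, known or untested is meant among the compounds shown, and "the series" means these compounds.

Of the compounds shown here, three built on a similar core have been tested in a functional assay on HL-60 cells (Homo sapiens) for cytotoxicity, read by CellTiter-Blue, with a stated time of 48 h; a higher number here means a weaker inhibitor, a lower number a stronger inhibitor. Compound 1 `COc1cc(OC)cc(-c2ccc3c(c2)C(CC(=O)OCC2CO2)C(C(=O)OCC2CO2)=C(N)O3)c1` reads > 80000 nM, which is a limit of the assay and not a number. Compound 2 `CCOC(=O)CC1C(C#N)=C(N)Oc2ccc(-c3cc(OC)cc(OC)c3)cc21` gives 19600 nM, while compound 3 `CCOC(=O)CC1C(C(=O)OCC)=C(N)Oc2ccc(-c3cccc(F)c3)cc21` gives 76400 nM. Compound 3 therefore holds the higher of the two true numbers, which makes it the weaker inhibitor of this pair, and the gap between them lies beyond the usual scatter of repeated measurements.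

The next compound changes a single group. Compound 4 `CCOC(=O)CC1C(C(=O)OCC)=C(N)Oc2ccc(-c3ccco3)cc21` is compound 3 with furan-2-yl in place of 3-fluorophenyl on an aromatic carbon. Among the measured compounds shown here, no two tested compounds differ in just one place, so the data give no direct measure of what a swap like this does. The expectation is therefore cautious: a small step in this assay towards a lower number, perhaps not much beyond the scatter, because compound 3 already stands at 76400 nM. The estimated move is a 1.5-fold lower number from compound 3 to compound 4 (0.18 log units; within the scatter). For compound 4 the estimated value is 50000 nM, with an expected range from 18000 nM to 80000 nM.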

Compound 4, half-maximal inhibitory concentration: > 80000 nM
Compound 4 gave a limit, no number; the forecaster's own chance of this, stated with the estimate: 25%; middle value at least 1.6-fold (0.20 log units) away from the limit.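

Among the compounds shown here, on this aromatic carbon of the shared core, the first change in one place that can be read in this assay is furan-2-yl in place of 3-fluorophenyl, and it gives an at least 1.0-fold higher number from compound 3 to compound 4 (0.01 log units; that floor lies within the scatter). Compound 4 reads > 80000 nM, which is a limit of the assay and not a number. The swap of a six-membered carbon ring for a five-membered ring with one oxygen therefore brought no move towards a lower number, and this step shows only a floor, so its true size cannot be read from this result: the limit of > 80000 nM in this assay, at which 2 of the 4 values shown sit.

The compounds shown leave open whether any group on this carbon can bring the number down, for example a phenyl ring carrying an amine or a carboxylic acid, or a pyridine ring in place of the furan. They also leave open whether furan-2-yl would behave the same way on a compound with the nitrile of compound 2, where a step in either direction could be read as a true number and not as a limit.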